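Switching the Amide Substituent on a Pyrazole-Type Statin Core

The source may hold more compounds than are shown below. What is called first, only, known or untested is meant among the compounds shown, and "the series" means these compounds.

Measured compounds:
- compound 1, `CC(C)c1c(C(=O)NCc2cccc(F)c2F)nn(-c2ccc(F)cc2)c1OC[C@@H](O)C[C@@H](O)CC(=O)O`, 2 nM
- compound 2, `CC(C)c1c(C(=O)N2CCC[C@H](c3ccccc3)C2)nn(-c2ccc(F)cc2)c1OC[C@@H](O)C[C@@H](O)CC(=O)O`, 4.8 nM
- compound 3, `COc1cccc(CNC(=O)c2nn(-c3ccc(F)cc3)c(OC[C@@H](O)C[C@@H](O)CC(=O)O)c2C(C)C)c1`, 16 nM

In an assay on microsomes from liver for inhibition of 3-hydroxy-3-methylglutaryl-coenzyme A reductase (Rattus norvegicus) (a lower number here means a stronger inhibitor, a higher number a weaker inhibitor), compound 2 stands second of the three numbers. Compound 1 sits closest to it, with a 2.4-fold higher number from compound 1 to compound 2 (0.38 log units; beyond the scatter), while compound 3 lies furthest away, with a 3.3-fold higher number from compound 2 to compound 3 (0.52 log units; beyond the scatter). Both steps are beyond the scatter but modest in size.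

Compound 4, `CC(C)c1c(C(=O)N(C)Cc2ccc(F)c(F)c2)nn(-c2ccc(F)cc2)c1OC[C@@H](O)C[C@@H](O)CC(=O)O`, is not yet measured. It differs from compound 2 in one place: (3,4-difluorobenzyl)(methyl)amino in place of 3-phenylpiperidin-1-yl on a carbonyl carbon. Among the measured compounds shown here, two measured steps bear on this change. Each replaces the group on the same carbonyl carbon: the change from a benzyl-type amine to 3-phenylpiperidin-1-yl gave a 2.4-fold higher number from compound 1 to compound 2 (0.38 log units; beyond the scatter), and the change from 3-phenylpiperidin-1-yl back to a benzyl-type amine gave a 3.3-fold higher number from compound 2 to compound 3 (0.52 log units; beyond the scatter). The two point in opposite directions, so no consistent trend emerges; the size of the benzyl-type amides depends on the aromatic substitution, and nothing measured carries a methyl on the amide nitrogen. Compound 4 is therefore expected to stay close to compound 2, with a step of a 1.2-fold lower number from compound 2 to compound 4 (0.08 log units; within the scatter), likely within or only just beyond the scatter. The estimate for compound 4 in this assay is 4 nM, with a range from 1.5 nM to 12 nM.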

Compound 4, half-maximal inhibitory concentration: 5.7 nM
Compound 4: middle estimate off by 1.4-fold (0.15 log units), on the low side; the range from low to high includes it.
By their numbers in this assay, from the lowest: compound 1; then compounds 2 and 4 (each within the scatter of the next); then compound 3.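

In this assay, the open-chain (3,4-difluorobenzyl)(methyl)amino group matches 3-phenylpiperidin-1-yl on this carbonyl carbon (a 1.2-fold higher number from compound 2 to compound 4 (0.07 log units; within the scatter)), so neither the six-membered non-aromatic ring nor its defined stereocentre is required for a number at this level. The two groups that keep the amide hydrogen fall on opposite sides of compound 4 (a 2.9-fold higher number from compound 1 to compound 4 (0.45 log units; beyond the scatter); a 2.8-fold lower number from compound 3 to compound 4 (0.45 log units; beyond the scatter)), but each of these steps also changes the aromatic substitution, so the share of the methyl cannot be separated. No available measurement explains any of these steps.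

From the compounds shown here alone, the effect of the methyl alone remains open, and the plain (3,4-difluorobenzyl)amino group on the same carbonyl carbon would isolate it. Also open, going by these compounds, is how an unsubstituted piperidin-1-yl group would compare with 3-phenylpiperidin-1-yl.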